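The source may report more compounds than this note shows. Statements on the series, on what has been measured and on what is new or still open speak of the compounds shown alone.

Measured in a functional assay on ECa-109 cells for inhibition, with ECa-109 cell line (Homo sapiens) as the target, read by sulforhodamine B assay; on this read-out lower numbers stand for stronger inhibition and higher numbers for weaker inhibition:
- compound 1 `CCCc1ccc(NC2=CC(=O)c3nc4n(c3C2=O)[C@H]2OC[C@@H](O)[C@H]2OC4)cc1`: > 4000 nM (a limit)
- compound 2 `O=C1C(Nc2ccc(Br)cc2)=CC(=O)c2c1nc1n2[C@H]2OC[C@@H](O)[C@H]2OC1`: 1980 nM
- compound 3 `O=C1C=C(NC2CCCCC2)C(=O)c2c1nc1n2[C@H]2OC[C@@H](O)[C@H]2OC1`: > 16000 nM (a limit)

Compound 2, at 1980 nM, is the only one of the three with a real number in this assay, so it cannot be ranked firmly against the others. The step to compound 4 `O=C1C(N2CCC2)=CC(=O)c2c1nc1n2[C@H]2OC[C@@H](O)[C@H]2OC1` is azetidin-1-yl in place of (4-bromophenyl)amino on a double-bonded ring carbon. In words, azetidin-1-yl takes the place of (4-bromophenyl)amino on a double-bonded ring carbon.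

Among the measured compounds shown here, the only measured step, a step that the two limits leave unreadable from compound 1 to compound 3, gives no size to carry over. Compound 1 stands at the limit of > 4000 nM in this assay, at which 1 of the 3 values shown sits. Compound 3 stands at the limit of > 16000 nM in this assay, at which 1 of the 3 values shown sits. Neither limit measures the loss of the (4-bromophenyl)amino group directly.

The closest guide is compound 3, which also carries no aromatic ring in this place and which reached the limit of > 16000 nM. Compound 1 tempers this reading, as it keeps an aromatic ring and still reached a limit, so an aromatic ring alone does not secure a number. Weaker inhibition is therefore expected, with a real chance of another limit. The expected change is a 3.0-fold higher number from compound 2 to compound 4 (0.48 log units; beyond the scatter), though its size is poorly constrained. For compound 4 the estimated value is 6000 nM, with an expected range from 1500 nM to 25000 nM.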

Compound 4, half-maximal inhibitory concentration: > 16000 nM
Compound 4: a limit, no number; the forecaster's own chance of this, stated with the estimate: 45%; middle value at least 2.6-fold (0.42 log units) from the limit.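

In this assay, compound 4 gives > 16000 nM, which is a limit of the assay and not a number. Placing azetidin-1-yl instead of (4-bromophenyl)amino on the double-bonded ring carbon gives an at least 8.0-fold higher number from compound 2 to compound 4 (0.90 log units; beyond the scatter), the first step among these compounds whose size can be read at all, and it shows that the number at this position depends on the group it carries. Among the compounds shown here, compound 2 remains the only compound with a real number, and the limit reached here is not a lone case: the limit of > 16000 nM in this assay, at which 2 of the 4 values shown sit.

The step from compound 1 to compound 3 cannot be read, and the readable step changes several things at once: the aromatic ring, the bromine and the amine hydrogen all leave together, so none of them can be credited with the number of compound 2 on its own. A plain phenylamino group without the bromine would test the halogen, while an N-methyl-(4-bromophenyl)amino group would test the amine hydrogen, and a piperidin-1-yl group would show whether a larger saturated ring on this carbon also ends at a limit.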